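Swapping the Aryl Group on a Piperidine Sulfonamide

This account rests on a few compounds, and the source may have more. Where it says the series, first, only, none or still open, it means among the compounds named here.

Measured compounds:
compound 1, `CC1CCN(C2CCN(S(=O)(=O)c3cccc(Br)c3)CC2)CC1`: 3.2 nM
compound 2, `Cc1cccc(S(=O)(=O)N2CCC(N3CCC(C)CC3)CC2)c1`: 25 nM

In a functional assay on DLD-1 cells (Homo sapiens) for antiproliferative activity, read by CellTiter-Glo, with a stated time of 72 h (a higher number here means a weaker inhibitor, a lower number a stronger inhibitor), compound 1 gives 3.2 nM, while compound 2 gives 25 nM. Compound 2 thus stands at the higher of the two measured numbers, the weaker inhibitor of the pair, and the gap between the two is a 7.8-fold higher number from compound 1 to compound 2 (0.89 log units; beyond the scatter), a step large enough to count.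

Compound 3, `CC1CCN(C2CCN(S(=O)(=O)c3ccc(Cl)cc3Cl)CC2)CC1`, has not yet been measured. It differs from compound 2 in one place: 2,4-dichlorophenyl in place of 3-methylphenyl on a sulfonyl sulfur. Among the measured compounds shown here, the only measured step that bears on this change is a 7.8-fold higher number from compound 1 to compound 2 (0.89 log units; beyond the scatter), in which the compound carrying a halogen on the aromatic ring was the stronger inhibitor. Moving from a methyl-bearing ring to a chlorine-bearing one is therefore expected to lower the number, though the new ring carries two chlorines in other places than the single bromo, so the size is uncertain. Compound 3 is expected to give 8 nM, in a range from 2 nM to 40 nM, an expected step of a 3.1-fold lower number from compound 2 to compound 3 (0.49 log units; beyond the scatter).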

Compound 3, half-maximal inhibitory concentration: 1 nM
Estimate against measurement, compound 3: 8.0-fold (0.90 log units) above; the measured number lies below the stated range.
By their numbers in this assay, from the lowest: compound 3; then compound 1; then compound 2.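

In this assay, the group on the sulfonyl sulfur proves able to move the number much further than the first pair showed: 2,4-dichlorophenyl in place of 3-methylphenyl gives a 25-fold lower number from compound 2 to compound 3 (1.40 log units; beyond the scatter), a large step. The same group also improves on the 3-bromophenyl group, with a 3.2-fold lower number from compound 1 to compound 3 (0.51 log units; beyond the scatter), so a single bromo did not mark the best result at this place. Among these three compounds, both halogen-bearing rings give lower numbers than the methyl-bearing ring, and the ring with two chlorines gives the lowest.

The compounds shown do not separate the two chlorines, so it stays open whether one alone would do as well. On these data alone, how a ring bearing a methoxy group or a nitrile would behave at this place also stays open. Nothing available explains the differences among these rings.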